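Shortening the chain on the aromatic nitrogen of compound 1

A few compounds are considered here, and "the series" means these few. Any claim that something is new, unique, unknown or untested is made for them only; others in the source may bear on it.

Compound 1 `CCn1cc(-c2ccccc2NCC2=NCCN2)cn1` gives 0% in a functional assay with Alpha-1D adrenergic receptor (Homo sapiens) as the target, read by calcium flux; on this read-out higher numbers stand for larger maximal responses and lower numbers for smaller maximal responses. Compound 2 `Cc1ccc(-c2ccccc2NCC2=NCCN2)n1C` gives 0% in this assay, so compound 1 stands level with compound 2 at the digits shown, within the scatter. Compound 3 `Cn1cc(-c2ccccc2NCC2=NCCN2)cn1` is still to be measured in this assay. It differs from compound 1 by hydrogen in place of methyl on a saturated chain carbon bound to an aromatic nitrogen. Among the compounds with values here, no step between two measured compounds bears on this change. The expected step is no change at the digits printed from compound 1 to compound 3 (within the scatter), none beyond the scatter in either direction. Compound 3 is expected at 0%, with a range from 0% to 10%.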

Compound 3, largest response reached (reported as maximal response), in percent of the reference or control that the assay uses: 0%
Compound 3: the middle estimate sits on the measured number at the digits printed, and the stated range covers the measured number.
By their numbers in this assay, from the lowest: compounds 1, 2 and 3 (each within the scatter of the next).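

Shortening the chain on the aromatic nitrogen from ethyl to methyl gives no change at the digits printed from compound 1 to compound 3 (within the scatter) in this assay, the first direct reading of a change at this position. With compound 3 at 0%, the methyl group gives no measurable maximal response at this position, and the ethyl group of compound 1 was not needed to reach this level. No supporting data bear on the reason for this result. Going by these compounds, whether a longer chain such as propyl, or an amine or a carboxylic acid carried on that chain, would give a maximal response in this assay stays open.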